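Swapping a Piperazine for a Piperidine on a Shared Core

The source may hold more compounds than are shown below. What is called first, only, known or untested is meant among the compounds shown, and "the series" means these compounds.

Measured in a functional assay on HepG2 cells (Homo sapiens) for inhibition, read by MTT assay, with a stated time of 48 h; on this read-out higher numbers stand for weaker inhibition and lower numbers for stronger inhibition:
Compound 1 `N#Cc1c(-c2ccc(Cl)cc2)nc2c(c(-c3ccccc3)nn2-c2ccccc2)c1-c1ccc(N2CCCCC2)cc1` gives 3210 nM.
Compound 2 `COc1ccc(-c2nc3c(c(-c4ccccc4)nn3-c3ccccc3)c(-c3ccc(N4CCN(C)CC4)cc3)c2C#N)cc1` gives 1330 nM.
Compound 3 `O=C(C=CNc1cc(-c2ccccc2)nn1-c1ccccc1)c1ccc(F)cc1` gives 59900 nM.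

Compound 2 has the lowest number of the three, so it is the strongest inhibitor here; compound 1 sits nearest, yet beyond the usual scatter, and compound 3 lies far off. Compound 4 `COc1ccc(-c2nc3c(c(-c4ccccc4)nn3-c3ccccc3)c(-c3ccc(N4CCCCC4)cc3)c2C#N)cc1` differs from compound 2 in one place: piperidin-1-yl in place of 4-methylpiperazin-1-yl on an aromatic carbon. Going by the values given here, no measured pair differs by exactly this change, so the step can only be estimated. Compound 1 also carries piperidin-1-yl and shows a higher number than compound 2, though it differs in a second place too. In this assay a modest weakening, or none beyond the scatter, is expected. Compound 4 is expected to give about 2500 nM, between 1000 nM and 6000 nM. The expected step from compound 2 to compound 4 is a 1.9-fold higher number from compound 2 to compound 4 (0.27 log units; within the scatter).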

Compound 4, half-maximal inhibitory concentration: 12500 nM
Beside the measured number, compound 4's estimate is 5.0-fold (0.70 log units) below it, and the stated range ends below it.
By their numbers in this assay, from the lowest: compound 2; then compound 1; then compound 4; then compound 3.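

In this assay piperidin-1-yl in place of 4-methylpiperazin-1-yl gives a 9.4-fold higher number from compound 2 to compound 4 (0.97 log units; beyond the scatter) and thus a clear loss of inhibition, so this position on the shared core responds strongly to the change of ring. Methoxy in place of chloro gives a 3.9-fold higher number from compound 1 to compound 4 (0.59 log units; beyond the scatter) and shows that a second place also moves the number. No measurement here explains either step.

As far as these compounds go, whether the second ring nitrogen or its methyl group matters stays open. Piperazin-1-yl without the methyl, or morpholin-4-yl, at this position would help separate the two.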